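Halogen swap on the isatin-like core, shorter linker

The source may report more compounds than this note shows. Statements on the series, on what has been measured and on what is new or still open speak of the compounds shown alone.

Three compounds of this series have been run in a functional assay on THP-1 cells (Homo sapiens) for inhibition, read by sulforhodamine B assay, with a stated time of 48 h, tested at 50 uM; a lower number here means less inhibition of growth, a higher number more inhibition of growth at the concentration tested. Compound 1, `O=C1C(=O)N(CCCCCn2cc(COc3cc(=O)oc4ccccc34)nn2)c2ccc(F)cc21`, gives 63%. Compound 2, `O=C1C(=O)N(CCCCCn2cc(COc3cc(=O)oc4ccccc34)nn2)c2ccc(Br)cc21`, gives 52%. Compound 3, `O=C1C(=O)N(CCCn2cc(COc3cc(=O)oc4ccccc34)nn2)c2ccc(F)cc21`, gives 86%, the highest of the three numbers, standing beyond the scatter from both of the others.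

Compound 1 and compound 2 differ in one place only: bromo in place of fluoro on an aromatic carbon. This change gave a number 11 percentage points lower from compound 1 to compound 2 (beyond the scatter). Compound 1 and compound 3 differ by more than one place, and the difference between the two cores is not broken down here.

Compound 4, `O=C1C(=O)N(CCCn2cc(COc3cc(=O)oc4ccccc34)nn2)c2ccc(Br)cc21`, has not yet been measured. It differs from compound 3 by bromo in place of fluoro on an aromatic carbon, the same change that separates compound 1 from compound 2, and at the same place; among the compounds shown it occurs twice in all.

With a single earlier instance to lean on, the expectation is that the step from compound 3 to compound 4 will be of similar size and direction, a number 11 percentage points lower from compound 3 to compound 4 (beyond the scatter), because compound 1 to compound 2 gave a number 11 percentage points lower from compound 1 to compound 2 (beyond the scatter). Among the measured compounds shown here, no second pair is available to test whether the step is constant across cores, so the range kept is wide. Compound 4 is accordingly expected to give 75% in this assay, estimated to lie between 60% and 88%.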

Compound 4, percent growth inhibition at one concentration: 72%
Compound 4: the middle estimate sits 3 percentage points above what was measured; low and high end bracket the measured number.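

Bromo in place of fluoro on the aromatic carbon gave a number 14 percentage points lower from compound 3 to compound 4 (beyond the scatter) in this assay. Set beside the earlier instance of the same change, the step carries over from the core of compound 1 to the core of compound 3 in direction, and its size does not differ between the two: the same change on two cores in this assay, a number 11 percentage points lower (beyond the scatter) from compound 1 to compound 2 and a number 14 percentage points lower (beyond the scatter) from compound 3 to compound 4, 3 percentage points apart, within the scatter of two such steps This shows only that the step held on these two cores, for this one pair of halogens at this one place and at the single concentration tested; it does not show that the step stays constant on other cores, and it gives no reason why the bromo compounds read lower.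

The compounds shown leave open how chloro, iodo or plain hydrogen on the same aromatic carbon would read, and therefore whether the numbers follow any order across the halogens rather than a difference between fluoro and bromo alone. Also open, going by these compounds, is whether the step survives on a core with a longer chain than either of those here, or with an amine or a carboxylic acid carried on the chain.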